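Trifluoromethylphenyl in Place of Methoxyphenyl on the Anilino Nitrogen

This account rests on a few compounds, and the source may have more. Where it says the series, first, only, none or still open, it means among the compounds named here.

Compound 1 `C#CCSc1nc(Nc2cccc(Cl)c2)c(C#N)c(-c2ccccc2)n1` reaches only a limit in a functional assay on MGC-803 cells (Homo sapiens) for inhibition, read by MTT assay, with a stated time of 72 h (a lower number here means a stronger inhibitor, a higher number a weaker inhibitor), reported as > 128000 nM. For the measured compounds named here, compound 2 `COc1ccc(Nc2nc(SCc3cn(Cc4ccccc4Cl)nn3)nc(-c3ccccc3)c2C#N)cc1` gives 7560 nM in this assay, the only finished number here, since the other value shown is the limit of > 128000 nM in this assay, at which 1 of the 2 values shown sits. Compound 3 `N#Cc1c(Nc2cccc(C(F)(F)F)c2)nc(SCc2cn(Cc3ccccc3Cl)nn2)nc1-c1ccccc1` differs from compound 2 by 3-(trifluoromethyl)phenyl in place of 4-methoxyphenyl on a nitrogen on an aromatic ring. Going by the values given here, no measured pair shows this change, so its step size is unknown. Compound 3 is expected to give 10000 nM, between 2500 nM and 40000 nM. The expected step is a 1.3-fold higher number from compound 2 to compound 3 (0.12 log units; within the scatter), modest in size and uncertain in direction, with a real chance that it ends at a limit.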

Compound 3, half-maximal inhibitory concentration: 22800 nM
Compound 3: middle estimate off by 2.3-fold (0.36 log units), on the low side; low and high end bracket the measured number.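

The position on the anilino nitrogen now has its first readable step in this assay, with 3-(trifluoromethyl)phenyl in place of 4-methoxyphenyl giving a 3.0-fold higher number from compound 2 to compound 3 (0.48 log units; beyond the scatter). This position therefore responds to the aryl group it carries, and this change weakens inhibition, though compound 3 still gives a finished number rather than a limit. Nothing shown here accounts for the step.

The two groups differ in both substituent and ring position, and the compounds shown do not separate these two changes. From the compounds shown here alone, how a plain phenyl or a piperidine would read at this position also remains open.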